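The source may hold more compounds than are shown below. What is called first, only, known or untested is meant among the compounds shown, and "the series" means these compounds.

Compound 1 `COc1ccc(/C=C\c2cc(OC)c(OC)c(OC)c2)cc1OCc1ccc(CNC(C)(C)C(=O)O)cc1` is the starting point of this account. In a functional assay on HeLa cells (Homo sapiens) for antiproliferative activity, read by CCK-8 assay, with a stated time of 48 h (on this read-out higher numbers stand for weaker inhibition and lower numbers for stronger inhibition), compound 1 gives > 10000 nM, which is a limit of the assay and not a number. Two measured neighbours carry the same core. Compound 2 `COc1ccc(/C=C\c2cc(OC)c(OC)c(OC)c2)cc1OCc1ccc(CN2CCCC[C@H]2C(=O)O)cc1` also returns a limit in this assay, at > 10000 nM. Compound 3 `COc1ccc(/C=C\c2cc(OC)c(OC)c(OC)c2)cc1OCc1ccc(CN2CCCCC2C(=O)O)cc1` gives 14200 nM in this assay. The step that the two limits leave unreadable from compound 1 to compound 2 cannot be sized because the limit of > 10000 nM in this assay, at which 2 of the 3 values shown sit, covers both ends, and a step that the limit leaves unreadable from compound 1 to compound 3 is likewise not readable, since one end is a limit. Compound 2 and compound 3 differ only in the fact that one of compounds 2 and 3 is drawn with a defined configuration and the other without, at the place where they differ, so a step that the limit leaves unreadable from compound 2 to compound 3 is also not readable. All three measured compounds therefore sit at or near the weak end of what this assay reports.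

Compound 4 `COc1ccc(/C=C\c2cc(OC)c(OC)c(OC)c2)cc1OCc1ccc(CN2CC(C(=O)O)C2)cc1` differs from compound 1 by 3-carboxyazetidin-1-yl in place of (1-carboxy-1-methylethyl)amino on a saturated chain carbon bound to an aromatic carbon. The steps from compound 1 to compound 2 and from compound 1 to compound 3 are the nearest comparisons, since each exchanges the same open-chain amino acid for a ring-bound one, and neither moved the read-out to a measurable number. Compound 4 is therefore expected to behave like its neighbours, with a step that the limit leaves unreadable from compound 1 to compound 4 expected to stay within the scatter. The estimate for compound 4 in this assay is 15000 nM, with a range from 5000 nM to 50000 nM, and a limit rather than a number is the more likely report.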

Compound 4, half-maximal inhibitory concentration: 6500 nM
Compound 4: the middle estimate sits 2.3-fold (0.36 log units) above what was measured, and the stated range covers the measured number.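

At the saturated chain carbon bound to an aromatic carbon, 3-carboxyazetidin-1-yl gives what the earlier groups did not, a step that can be sized in this assay: a 2.2-fold lower number from compound 3 to compound 4 (0.34 log units; beyond the scatter). Against the other two neighbours only a floor can be given, with an at least 1.5-fold lower number from compound 1 to compound 4 (0.18 log units; that floor lies within the scatter) and an at least 1.5-fold lower number from compound 2 to compound 4 (0.18 log units; that floor lies within the scatter), so these two steps alone do not set compound 4 apart from compound 1 or compound 2. Those two steps remain floors, and the steps among compound 1, compound 2 and compound 3 cannot be read, because of the limit: the limit of > 10000 nM in this assay, at which 2 of the 4 values shown sit.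

Going by these compounds, what a 3-carboxypiperidin-1-yl group, or a methyl ester in place of the carboxylic acid, would give at this place remains open, so the size of the ring and the place of the carboxylic acid on it cannot be told apart in the step to compound 4. Whether the configuration of the 2-carboxypiperidin-1-yl group matters also stays unresolved, and the one comparison that bears on it rests on a difference in drawing: the fact that one of compounds 2 and 3 is drawn with a defined configuration and the other without, at the place where they differ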